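This account rests on a few compounds, and the source may have more. Where it says the series, first, only, none or still open, it means among the compounds named here.

Measured compounds:
compound 1 `COC(=O)c1ccc(N2CCC(O)(Cn3cnc4c(Br)n(C)nc4c3=O)CC2)c(Cl)c1`: 157 nM
compound 2 `N#Cc1ccc(CN2CCC(O)(Cn3cnc4c(cnn4-c4ccc(F)cc4)c3=O)CC2)cc1`: "not determined" (no result reported)
compound 3 `O=c1c2cnn(-c3ccc(F)cc3)c2ncn1CC1(O)CCN(Cc2ccc(C(F)(F)F)cc2)CC1`: "not determined" (no result reported)

Among the measured compounds shown here, compound 3 has no number in an assay on Sf21 cells for inhibition of ubiquitin carboxyl-terminal hydrolase 7 (Homo sapiens), read by spectrophotometry, with stated times of 30 min and 2 h (on this read-out lower numbers stand for stronger inhibition and higher numbers for weaker inhibition), and compound 2, its companion with the same core, has none either; only compound 1 offers a measured value, and it differs from compound 3 in more than one place, so no step to compound 3 can be read from it. Compound 4 `COC(=O)c1ccc(CN2CCC(O)(Cn3cnc4c(cnn4-c4ccc(F)cc4)c3=O)CC2)c(Cl)c1` arises from compound 3 by one change: 2-chloro-4-(methoxycarbonyl)phenyl in place of 4-(trifluoromethyl)phenyl on a saturated chain carbon bound to an amine nitrogen in a ring. For the measured compounds named here, with no measured pair showing this change, its size and direction in this assay cannot be drawn from the data; the estimate below leans only on the value of compound 1 in this assay as the single anchor. Compound 4 is expected to give about 300 nM, within 40 nM to 3000 nM.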

Compound 4, half-maximal inhibitory concentration: 800 nM
Compound 4: the middle estimate sits 2.7-fold (0.43 log units) below what was measured; low and high end bracket the measured number.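

No new step can be read: compound 4 has a number, while compound 3 has none to compare it with. On these data alone, how swapping the benzyl group changes inhibition stays open. Nothing shown here explains the result.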